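Compound 2 to compound 4: a change of fluorines

The source may report more compounds than this note shows. Statements on the series, on what has been measured and on what is new or still open speak of the compounds shown alone.

Measured in an ADME assay on MDCK cells (Canis lupus familiaris) for cytotoxicity, read by CCK-8 assay, with a stated time of 72 h; a higher number here means a weaker inhibitor, a lower number a stronger inhibitor:
- Compound 1 `NC(=S)N/N=C(/C=C/c1ccc(OC(F)(F)F)cc1)c1nc2ccccc2[nH]1`: 0.34 ug/mL
- Compound 2 `NC(=S)N/N=C(/C=C/c1ccc(F)cc1)c1nc2ccccc2[nH]1`: 1.6 ug/mL
- Compound 3 `NC(=S)N/N=C(/C=C/c1cccc2[nH]ccc12)c1nc2ccccc2[nH]1`: 0.91 ug/mL

Compound 2, at 1.6 ug/mL, lies within the usual scatter of compound 3 and clearly above compound 1. Compound 4 `NC(=S)N/N=C(/C=C/c1cc(F)cc(F)c1)c1nc2ccccc2[nH]1` differs from it by 3,5-difluorophenyl in place of 4-fluorophenyl on a double-bonded chain carbon bound to a double-bonded chain carbon, with 3,5-difluorophenyl in place of 4-fluorophenyl. Among the measured compounds shown here, only one measured step bears on this: a 4.7-fold higher number from compound 1 to compound 2 (0.67 log units; beyond the scatter). That modest step exchanged fluoro for trifluoromethoxy, a different swap, so it offers only a loose guide. For the measured compounds named here, no measured compound carries two fluorines. In this assay, the expected step is a 1.2-fold lower number from compound 2 to compound 4 (0.09 log units; within the scatter), within the scatter and without a firm direction. In this assay, compound 4 is estimated at 1.3 ug/mL, with an expected range from 0.5 ug/mL to 3.4 ug/mL.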

Compound 4, half-maximal inhibitory concentration: 1.6 ug/mL
The estimate for compound 4 lay 1.2-fold (0.09 log units) below the measured number; low and high end bracket the measured number.
By their numbers in this assay, from the lowest: compound 1; then compounds 3, 2 and 4 (each within the scatter of the next).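

In this assay, 3,5-difluorophenyl in place of 4-fluorophenyl gives no measurable shift (no change at the digits printed from compound 2 to compound 4 (within the scatter)). This is the first pair shown that differs only in its fluorines, and here a change in their number and placement leaves the cytotoxicity reading unmoved. Nothing measured here offers an explanation for this result.

This single step cannot separate the effect of adding a fluorine from that of moving one. It also leaves open whether an amine or a carboxylic acid on this ring would shift the number.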